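A Halogen Swap at the Limit of Microsomal Stability

The source may report more compounds than this note shows. Statements on the series, on what has been measured and on what is new or still open speak of the compounds shown alone.

Measured in an ADME assay on microsomes from liver (Rattus norvegicus) for metabolic stability; on this read-out higher numbers stand for a longer-lived compound and lower numbers for a shorter-lived compound; each entry is a limit of the assay, not a number:
- Compound 1 `Nc1nc(NCCNc2ncc(-c3ncc[nH]3)c(-c3cc(F)ccc3F)n2)ccc1[N+](=O)[O-]`: > 0.5 h
- Compound 2 `Nc1nc(NCCNc2ncc(-c3ncc[nH]3)c(-c3ccc(F)cc3Cl)n2)ccc1[N+](=O)[O-]`: > 0.5 h
- Compound 3 `Nc1nc(NCCNc2ncc(-c3ncc[nH]3)c(-c3cc(F)c(Cl)cc3Cl)n2)ccc1[N+](=O)[O-]`: > 0.5 h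

Compound 3 stands only at a limit, > 0.5 h. The other two compounds offer no firmer reference, and the whole set shares one mark: the limit of > 0.5 h in this assay, at which 3 of the 3 values shown sit.

The change under consideration leads to compound 4 `Nc1nc(NCCNc2ncc(-c3ncc[nH]3)c(-c3ccc(Br)cc3Cl)n2)ccc1[N+](=O)[O-]`. On an aromatic carbon, 4-bromo-2-chlorophenyl takes the place of 2,4-dichloro-5-fluorophenyl: 4-bromo-2-chlorophenyl in place of 2,4-dichloro-5-fluorophenyl on an aromatic carbon.

Among the compounds with values here, three measured steps bear on this change, all of them among aryl groups at the same place: a step that the two limits leave unreadable from compound 1 to compound 2, a step that the two limits leave unreadable from compound 1 to compound 3 and a step that the two limits leave unreadable from compound 2 to compound 3. None has a readable size, so neither a size nor a direction can be carried over from them. In this assay, no step beyond the usual scatter is therefore expected, and any expected direction remains weak. The expected step is a step that the limit leaves unreadable from compound 3 to compound 4. Compound 4 may well be reported as a limit too. For compound 4 the estimate is 0.8 h, with an expected range from 0.4 h to 2 h.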

Compound 4, half-life: > 0.5 h
Compound 4 ended at the assay's limit; the forecaster's own chance of this, stated with the estimate: 70%; the middle value does not contradict the limit.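

In this assay compound 4 gives > 0.5 h, which is a limit of the assay and not a number. Its steps from compound 1, compound 2 and compound 3 therefore cannot be read, and the whole set shares one mark: the limit of > 0.5 h in this assay, at which 4 of the 4 values shown sit.

The compounds shown leave open how long any of the four actually lasts, and whether their aryl groups differ at all on this read-out.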